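From a dimethylamino chain to a propargyl amide

A few compounds are considered here, and "the series" means these few. Any claim that something is new, unique, unknown or untested is made for them only; others in the source may bear on it.

- compound 1 `CCOC(=O)CN(C)C(=O)c1ccc(C(CC)(CC)c2ccc(OCC(O)C(C)(C)C)c(C)c2)n1CC` 10100 nM
- compound 2 `CCN(CC)CCNC(=O)c1ccc(C(CC)(CC)c2ccc(OCC(O)C(C)(C)C)c(C)c2)n1CC` 2500 nM
- compound 3 `CCn1c(C(=O)NCCCN(C)C)ccc1C(CC)(CC)c1ccc(OCC(O)C(C)(C)C)c(C)c1` 470 nM

In an ADME assay on L02 cells (Homo sapiens) for cytotoxicity, read by MTT assay, with a stated time of 48 h (on this read-out higher numbers stand for weaker inhibition and lower numbers for stronger inhibition), compound 3 has the lowest number of the three, at 470 nM. The next compound, compound 4 `C#CCNC(=O)c1ccc(C(CC)(CC)c2ccc(OCC(O)C(C)(C)C)c(C)c2)n1CC`, keeps the shared core and changes only the amide side chain: ethynyl in place of 2-(dimethylamino)ethyl on a saturated chain carbon bound to an amide-type nitrogen. In words, ethynyl takes the place of 2-(dimethylamino)ethyl, which turns the 3-(dimethylamino)propyl chain into propargyl.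

Like compound 4, compound 1 has no dimethylamino or diethylamino group in that side chain, so compound 1 at 10100 nM is the closest guide. Two measured steps add such a group: a 4.0-fold lower number from compound 1 to compound 2 (0.61 log units; beyond the scatter) and a 21-fold lower number from compound 1 to compound 3 (1.33 log units; beyond the scatter). The choice of chain also matters, as a 5.3-fold lower number from compound 2 to compound 3 (0.73 log units; beyond the scatter) shows. Among the measured compounds shown here, removing the dimethylamino group should therefore largely reverse the biggest of these steps, although no measured compound carries a propargyl group.

The expected change is a 15-fold higher number from compound 3 to compound 4 (1.17 log units; beyond the scatter), a large rise in the number. For compound 4 the estimated value is 7000 nM, with an expected range of 2500 nM to 20000 nM.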

Compound 4, half-maximal inhibitory concentration: 4400 nM
The estimate for compound 4 lay 1.6-fold (0.20 log units) above the measured number; the range from low to high includes it.
By their numbers in this assay, from the lowest: compound 3; then compounds 2 and 4 (each within the scatter of the next); then compound 1.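

In this assay, the swap from the 3-(dimethylamino)propyl chain to propargyl gives a 9.4-fold higher number from compound 3 to compound 4 (0.97 log units; beyond the scatter) and so loses much of the drop seen in compound 3. Even so, the propargyl amide, with no amine in its side chain, gives a 2.3-fold lower number from compound 1 to compound 4 (0.36 log units; beyond the scatter), so a side chain without an amine need not match compound 1, while a 1.8-fold higher number from compound 2 to compound 4 (0.25 log units; within the scatter) lies within the scatter and leaves compound 4 level with compound 2. No measurement here explains these differences.

A plain propyl amide would show whether the triple bond itself matters. As far as these compounds go, it also remains open how a primary amine at the end of the propyl chain, or a longer chain ending in dimethylamino, would compare with compound 3.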